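A few compounds are considered here, and "the series" means these few. Any claim that something is new, unique, unknown or untested is made for them only; others in the source may bear on it.

Compound 3 `Cc1cc(F)ccc1Cc1c(C)c2ccc(OCC(O)CN3CCC(C(N)=O)CC3)cc2oc1=O` stands at the ceiling of what an ADME assay on A549 cells (Homo sapiens) for cytotoxicity, read by CellTiter-Glo (on this read-out higher numbers stand for lower toxicity in this test and lower numbers for higher toxicity in this test), reports: in this assay compound 3 gives > 100000 nM, which is a limit of the assay and not a number. Compound 1 `Cc1cc(=O)oc2cc(OCC(O)CN3CCC(C(N)=O)CC3)ccc12` stands at the same limit, and in this assay compound 1 gives > 100000 nM. Among the measured compounds shown here, compound 2 `Cc1c(Cc2ccc(F)cc2)c(=O)oc2cc(OCC(O)CN3CCC(C(N)=O)CC3)ccc12` is the only one with a number; in this assay compound 2 gives 89300 nM. the limit of > 100000 nM in this assay, at which 2 of the 3 values shown sit, is where two of the three values sit, so the steps read only as floors or not at all: an at least 1.1-fold lower number from compound 1 to compound 2 (0.04 log units; that floor lies within the scatter), an at least 1.1-fold higher number from compound 2 to compound 3 (0.04 log units; that floor lies within the scatter) and a step that the two limits leave unreadable from compound 1 to compound 3. Compound 4 `Cc1c(Cc2ccc(F)cc2Cl)c(=O)oc2cc(OCC(O)CN3CCC(C(N)=O)CC3)ccc12` differs from compound 3 by chloro in place of methyl on an aromatic carbon. For the measured compounds named here, no measured step involves a chloro group, and the two steps that do change the benzyl group stayed within the scatter or were unreadable, so the expected step in this assay is none beyond the scatter, a number no higher from compound 3 to compound 4 (the limit leaves the size open). For compound 4 the estimate in this assay is 100000 nM, expected to fall between 50000 nM and 200000 nM.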

Compound 4, half-maximal cytotoxic concentration: 90800 nM
Estimate against measurement, compound 4: 1.1-fold (0.04 log units) above; measured number inside the range.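

Chloro in place of hydrogen on this aromatic carbon, ortho to a large group, gives a 1.0-fold higher number from compound 2 to compound 4 (0.01 log units; within the scatter) in this assay, and this is the only new step with a number at both ends. Chloro in place of methyl gives an at least 1.1-fold lower number from compound 3 to compound 4 (0.04 log units; that floor lies within the scatter), and 2-chloro-4-fluorobenzyl in place of hydrogen gives an at least 1.1-fold lower number from compound 1 to compound 4 (0.04 log units; that floor lies within the scatter). These two steps read only as floors because of the limit: the limit of > 100000 nM in this assay, at which 2 of the 4 values shown sit.

As far as these compounds go, how large the step from methyl to chloro really is stays open, as does whether a methoxy group or an amine at this position would move the number beyond the scatter. Also open, from the compounds shown here alone, is whether a carboxylic acid in place of the carboxamide would change the read-out with these benzyl groups in place.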